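This account rests on a few compounds, and the source may have more. Where it says the series, first, only, none or still open, it means among the compounds named here.

In an ADME assay on MRC5 cells (Homo sapiens) for cytotoxicity, read by fluorescence and resazurin assay, with a stated time of 3 days (on this read-out higher numbers stand for weaker inhibition and lower numbers for stronger inhibition), compound 1 (`Cc1cn(C2CCN(Cc3cccc(Oc4cccc(F)c4)c3)CC2)c(=O)[nH]c1=O`) gives > 64000 nM, which is a limit of the assay. Compound 2 (`Cc1cn(C2CCN(Cc3cccc(Oc4ccccn4)c3)CC2)c(=O)[nH]c1=O`) gives > 64000 nM, again only a limit. Among the compounds with values here, the one measured step is a step that the two limits leave unreadable from compound 1 to compound 2, so it offers no size to carry forward. Compound 3 (`COc1cccc(Oc2cccc(CN3CCC(n4cc(C)c(=O)[nH]c4=O)CC3)c2)c1`) differs from compound 2 by 3-methoxyphenyl in place of pyridin-2-yl on an oxygen on an aromatic ring. The expectation rests on (the limit of > 64000 nM in this assay, at which 2 of the 2 values shown sit), and no change beyond the scatter is expected. The expected step is an at least 1.0-fold lower number from compound 2 to compound 3 (0.02 log units; that floor lies within the scatter). Compound 3 is estimated at 60000 nM, with an expected range from 30000 nM to 64000 nM.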

Compound 3, half-maximal inhibitory concentration: 25300 nM
Beside the measured number, compound 3's estimate is 2.4-fold (0.38 log units) above it; the measured number lies below the stated range.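

In this assay, compound 3 alone among the three gives a number rather than a limit, so the group on this oxygen can move the read-out. The change to 3-methoxyphenyl is an at least 2.5-fold lower number from compound 2 to compound 3 (0.40 log units; beyond the scatter), and methoxy in place of fluoro is an at least 2.5-fold lower number from compound 1 to compound 3 (0.40 log units; beyond the scatter). Both sizes are floors, and the step between the other two compounds still cannot be read: the limit of > 64000 nM in this assay, at which 2 of the 3 values shown sit.

From the compounds shown here alone, how far these steps truly run stays open. So does whether an amine or a carboxylic acid in place of the methoxy would lower the number further or return it to the limit.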